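Compound 3: One Nitrogen Substituent Changes

This account rests on a few compounds, and the source may have more. Where it says the series, first, only, none or still open, it means among the compounds named here.

Compound 1 (`CC(C)(c1cc(Cl)cc(Cl)c1)N1CCC(COc2cc(F)c(C(=O)NS(C)(=O)=O)cc2C2CC2)CC1`) gives 7.8 mL/min/kg
Compound 2 (`CS(=O)(=O)NC(=O)c1cc(C2CC2)c(OCC2CCN(C(=O)c3cc(Cl)cc(Cl)c3)CC2)cc1F`) gives 8.6 mL/min/kg

Among the compounds with values here, both compounds were tested in an ADME assay on microsomes from liver (Homo sapiens) for metabolic stability, read by LC-MS, using NADPH, with a stated time of 60 min, tested at 1 uM (a lower number here means slower removal, a higher number faster removal of the compound), and cannot be told apart: compound 2 stands level with compound 1, the only other compound measured so far. Compound 3 (`CS(=O)(=O)NC(=O)c1cc(C2CC2)c(OCC2CCN(Cc3ccc(Cl)cc3)CC2)cc1F`) has not yet been measured. It carries 4-chlorobenzyl in place of (3,5-dichlorophenyl)carbonyl on an amine nitrogen in a ring.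

Within the data shown here, only one measured step bears on this change. That step, a 1.1-fold higher number from compound 1 to compound 2 (0.04 log units; within the scatter), put (3,5-dichlorophenyl)carbonyl in place of 1-(3,5-dichlorophenyl)-1-methylethyl on the same nitrogen, and it stayed within the scatter. Among the measured compounds shown here, no measured compound carries 4-chlorobenzyl, so this single step is weak evidence. Even so, it gives no reason to expect a large shift, and no direction can be favoured with confidence. The estimated change is a 1.0-fold higher number from compound 2 to compound 3 (0.02 log units; within the scatter), which is no larger than the scatter. For compound 3 the expected clearance is 9 mL/min/kg (estimated range 5 mL/min/kg to 16 mL/min/kg).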

Compound 3, clearance: 9.9 mL/min/kg
For compound 3 the middle estimate is 1.1-fold (0.04 log units) below the measured one; the measured number falls inside the stated range.
By their numbers in this assay, from the lowest: compounds 1, 2 and 3 (each within the scatter of the next).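

In this assay, putting 4-chlorobenzyl on the ring nitrogen gives a 1.2-fold higher number from compound 2 to compound 3 (0.06 log units; within the scatter) and a 1.3-fold higher number from compound 1 to compound 3 (0.10 log units; within the scatter), so neither step can be told apart from repeat-to-repeat variation. The earlier compounds shown here showed this only for two groups that both carry a 3,5-dichlorophenyl ring, whereas this result extends it to a group with one chlorine instead of two and no carbonyl, so across these three compounds the nitrogen substituent can differ in these ways while the clearance numbers remain within the scatter of each other. No measurement shown here explains why these numbers stay so close.

From the compounds shown here alone, the step from compound 2 to compound 3 changes the carbonyl, the number of chlorines and their placement on the ring all at once, so the effect of each one alone remains unknown, and a small net step could even hide opposing effects. All three groups also carry a chlorinated benzene ring, which leaves open whether the numbers would stay this close with a different kind of group on this nitrogen, such as a pyridine ring or a carboxylic acid on a longer chain.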